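The source may hold more compounds than are shown below. What is called first, only, known or untested is meant among the compounds shown, and "the series" means these compounds.

Of the compounds shown here, three have so far been tested in a functional assay on A549 cells (Homo sapiens) for inhibition, read by MTT assay, with a stated time of 48 h; on this read-out higher numbers stand for weaker inhibition and lower numbers for stronger inhibition. Compound 1 `Cn1c(/C=C2\SC(=O)N(CC(=O)N3CCOCC3)C2=O)nc2ccccc21` gives 38500 nM in this assay. Compound 2 `CC(C)n1c(/C=C2\SC(=O)N(CC(=O)N3CCOCC3)C2=O)nc2ccccc21` reaches only the limit of this assay, > 50000 nM, which is a boundary of the measurement and not a number. Compound 3 `COc1cc2c(cc1OC)CN(C(=O)CN1C(=O)S/C(=C\c3nc4ccccc4n3C(C)C)C1=O)CC2` gives 20600 nM in this assay; the value closest to it is that of compound 1, and the two lie within the usual scatter of each other. The difference between the core of compound 2 and the core of compound 3 is not broken down here.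

Compound 4 `COc1cc2c(cc1OC)CN(C(=O)CN1C(=O)S/C(=C\c3nc4ccccc4n3C)C1=O)CC2` has not yet been measured in this assay. It differs from compound 3 in one place: methyl in place of isopropyl on an aromatic nitrogen. The same change has already been made once, from compound 2 to compound 1: methyl in place of isopropyl on an aromatic nitrogen. That step produced an at least 1.2-fold lower number from compound 2 to compound 1 (0.11 log units; that floor lies within the scatter), though its starting point is the limit of > 50000 nM in this assay, at which 1 of the 3 values shown sits, so the true size of that step is not known. A step of similar size is expected here, a 1.4-fold lower number from compound 3 to compound 4 (0.14 log units; within the scatter), resting on the measured step of an at least 1.2-fold lower number from compound 2 to compound 1 (0.11 log units; that floor lies within the scatter). Compound 4 is accordingly estimated at 15000 nM, most likely between 6000 nM and 40000 nM.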

Compound 4, half-maximal inhibitory concentration: 13400 nM
For compound 4 the middle estimate is 1.1-fold (0.05 log units) above the measured one; measured number inside the range.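

In this assay, putting methyl in place of isopropyl on the aromatic nitrogen gives a 1.5-fold lower number from compound 3 to compound 4 (0.19 log units; within the scatter), so on this core the change has no effect that can be told apart from assay noise. Set beside the same change on the other core, the result offers no sign of a clear gain on either core, but it cannot establish that the change carries over with the same size: the same change on two cores in this assay, an at least 1.2-fold lower number (0.11 log units; that floor lies within the scatter) from compound 2 to compound 1 and a 1.5-fold lower number (0.19 log units; within the scatter) from compound 3 to compound 4; the limit leaves it open whether they differ. From the compounds shown here alone, compound 2 gives > 50000 nM, which is a limit and not a number, so the size of the earlier step stays unknown and two small steps cannot be matched with confidence: the limit of > 50000 nM in this assay, at which 1 of the 4 values shown sits.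

The compounds shown leave open whether another group on that nitrogen, such as ethyl, cyclopropyl or benzyl, would move the number beyond the usual scatter. They also leave open how the same change would read on a core whose amide part carries a different amine, such as piperazine.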